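Cytotoxicity of a benzimidazole thioether amide series on Vero cells

The source may hold more compounds than are shown below. What is called first, only, known or untested is meant among the compounds shown, and "the series" means these compounds.

Measured compounds:
compound 1 `COc1ccc(-n2c(SC(C)C(=O)Nc3nc(C)c(Br)cc3Br)nc3ccccc32)cc1` — 9700 nM
compound 2 `COc1ccc(-n2c(SC(C)C(=O)Nc3nc(C)cc(Cl)n3)nc3ccccc32)cc1` — "not determined" (no result reported)
compound 3 `COc1ccc(-n2c(SC(C)C(=O)Nc3cc(Br)ccc3Br)nc3ccccc32)cc1` — "not determined" (no result reported)

In an ADME assay on Vero cells (Chlorocebus sabaeus) for cytotoxicity, read by MTT assay, with a stated time of 24 h (on this read-out lower numbers stand for higher toxicity in this test and higher numbers for lower toxicity in this test), only compound 1 has a number, and that is 9700 nM. Compound 2 and compound 3 stand without a result in this assay, so compound 3 has no position on the numbers shown, and a second entry is likewise empty. Compound 4 `COc1ccc(-n2c(SC(C)C(=O)Nc3ncc(C)cc3Cl)nc3ccccc32)cc1` is the next to be measured. It differs from compound 3 by 3-chloro-5-methylpyridin-2-yl in place of 2,5-dibromophenyl on an amide-type nitrogen. Going by the values given here, no measured step is available, so no size can be attached to this change in this assay. The closest point of reference is compound 1 with 9700 nM. Compound 4 is therefore expected to give around 10000 nM, within a range from 3000 nM to 40000 nM.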

Compound 4, half-maximal cytotoxic concentration: 880 nM
Estimate against measurement, compound 4: 11-fold (1.06 log units) above; measured number outside the range, below it.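

In this assay, the group on the amide-type nitrogen proves able to shift the read-out: 3-chloro-5-methylpyridin-2-yl in place of 3,5-dibromo-6-methylpyridin-2-yl gives an 11-fold lower number from compound 1 to compound 4 (1.04 log units; beyond the scatter) and so higher toxicity in this test. The step from compound 3 cannot be read, as compound 3 has no number. Nothing available here explains this step.

Which part of the difference between these two groups carries the step remains open. So does the effect of an amine or a carboxylic acid in place of the chlorine in 3-chloro-5-methylpyridin-2-yl.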